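This account rests on a few compounds, and the source may have more. Where it says the series, first, only, none or still open, it means among the compounds named here.

Measured compounds:

Compound 1, `O=c1[nH]cc(S(=O)(=O)Nc2ccccc2-c2cn(-c3ccccc3F)nn2)c(=O)[nH]1` — in a functional assay on OVCAR-3 cells (Homo sapiens) for antiproliferative activity, read by MTT assay, with a stated time of 24 h (a higher number here means a weaker inhibitor, a lower number a stronger inhibitor), compound 1 gives 15300 nM.
Compound 2, `O=c1[nH]cc(S(=O)(=O)Nc2ccccc2-c2cn(-c3cccc(F)c3)nn2)c(=O)[nH]1` — in this assay compound 2 gives > 20000 nM, which is a limit of the assay and not a number.
Compound 3, `O=c1[nH]cc(S(=O)(=O)Nc2ccc(-c3cn(-c4ccccc4F)nn3)cc2)c(=O)[nH]1` — in this assay compound 3 gives 8030 nM.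

Compound 4, `O=c1[nH]cc(S(=O)(=O)Nc2ccc(-c3cn(-c4cccc(F)c4)nn3)cc2)c(=O)[nH]1`, has not yet been measured.

Within the data shown here, the only change between compound 1 and compound 2 is 3-fluorophenyl in place of 2-fluorophenyl on an aromatic nitrogen. This change gave an at least 1.3-fold higher number from compound 1 to compound 2 (0.11 log units; that floor lies within the scatter). Its size cannot be pinned down more closely, since compound 2 sits at the limit of > 20000 nM in this assay, at which 1 of the 3 values shown sits. Compound 3 shares the same change of core relative to compound 1, but the difference between the two cores is not broken down here; their values in this assay lie within the usual scatter of each other.

Compound 4 stands to compound 3 exactly as compound 2 stands to compound 1: the change is 3-fluorophenyl in place of 2-fluorophenyl on an aromatic nitrogen, the same change, at the same place. Among the measured compounds shown here, the step from compound 3 to compound 4 is expected to be a 1.5-fold higher number from compound 3 to compound 4 (0.17 log units; within the scatter), because the same change from compound 1 to compound 2 gave an at least 1.3-fold higher number from compound 1 to compound 2 (0.11 log units; that floor lies within the scatter) and that is the only guide available. Compound 4 is therefore expected to give about 12000 nM in this assay, most likely between 5000 nM and 30000 nM.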

Compound 4, half-maximal inhibitory concentration: > 20000 nM
Compound 4: only a limit was reported; the forecaster's own chance of this, stated with the estimate: 25%; middle value at least 1.6-fold (0.22 log units) away from the limit.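

In this assay, putting 3-fluorophenyl in place of 2-fluorophenyl on the core of compound 3 gives an at least 2.4-fold higher number from compound 3 to compound 4 (0.39 log units; beyond the scatter), so on this core the change clearly raises the number. Compound 4 gives > 20000 nM, which is a limit of the assay and not a number. The same change on the core of compound 1 has a floor that lies within the scatter, so the data do not show that the size of the step carries from one core to the other, nor that it differs between them: the same change on two cores in this assay, an at least 1.3-fold higher number (0.11 log units; that floor lies within the scatter) from compound 1 to compound 2 and an at least 2.4-fold higher number (0.39 log units; beyond the scatter) from compound 3 to compound 4; the limit leaves it open whether they differ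

On these data alone, the true values of compound 2 and compound 4 remain unknown, and so does the real size of either step: the limit of > 20000 nM in this assay, at which 2 of the 4 values shown sit. Also open is how the series would respond if an amine or a carboxylic acid took the place of the fluorine on this phenyl ring.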